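The source may report more compounds than this note shows. Statements on the series, on what has been measured and on what is new or still open speak of the compounds shown alone.

Compound 1 `CC(=O)c1ccc(OCc2ccc(C)cc2)cc1` and compound 2 `CC(=O)c1ccc(OCc2ccc(Cl)cc2)cc1` share one core and differ in a single place. In an assay on isolated protein for inhibition of Amine oxidase [flavin-containing] B (Homo sapiens), read by Amplex Red, with a stated time of 15 min (a higher number here means a weaker inhibitor, a lower number a stronger inhibitor), compound 1 gives 102 nM, and in this assay compound 2 gives 63.2 nM. Among the measured compounds shown here, the only measured step, a 1.6-fold lower number from compound 1 to compound 2 (0.21 log units; within the scatter), lies within the scatter, so these two numbers cannot be told apart. Of the two numbers shown, compound 2 holds the smaller one, with compound 1 as its nearest neighbour at a gap that falls within the scatter.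

Compound 3 `CC(=O)c1ccc(OCc2ccc(C(F)(F)F)cc2)cc1` has not yet been measured. Its change from compound 2 is trifluoromethyl in place of chloro on an aromatic carbon. For the measured compounds named here, no measured compound carries a trifluoromethyl group, so nothing measured bears directly on this exchange. Going by the values given here, the one step that touches that aromatic carbon, a 1.6-fold lower number from compound 1 to compound 2 (0.21 log units; within the scatter), was within the scatter, which hints that swapping one small group for another there changes little. In this assay the step is therefore expected to be small, a 1.0-fold higher number from compound 2 to compound 3 (0.01 log units; within the scatter), with no direction beyond the scatter. Compound 3 is estimated at 65 nM in this assay, within a range of 20 nM to 210 nM.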

Compound 3, half-maximal inhibitory concentration: 77.8 nM
Compound 3: middle estimate off by 1.2-fold (0.08 log units), on the low side, and the stated range covers the measured number.
By their numbers in this assay, from the lowest: compounds 2, 3 and 1 (each within the scatter of the next).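

Replacing chloro with trifluoromethyl on this aromatic carbon, para to a large group, gives a 1.2-fold higher number from compound 2 to compound 3 (0.09 log units; within the scatter) in this assay, and replacing methyl with trifluoromethyl gives a 1.3-fold lower number from compound 1 to compound 3 (0.12 log units; within the scatter), so none of the steps among these three groups can be told from the scatter. Trifluoromethyl brings 4 heavy atoms where chloro has 1, which shows that, for this one exchange, a higher count of heavy atoms at this place comes with no step beyond the scatter, something the earlier exchange of methyl for chloro could not show. There is no measured evidence to explain why the three numbers stay this close.

The compounds shown leave open whether this place stays as flat with a different kind of group, such as an amine, a carboxylic acid or a longer chain. They also leave open whether changes elsewhere on the shared core, for example replacing the carbonyl or moving the group to another carbon of the same ring, would produce a step that stands clear of the scatter.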